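A few compounds are considered here, and "the series" means these few. Any claim that something is new, unique, unknown or untested is made for them only; others in the source may bear on it.

Compound 3 `CCCCCCOC(=O)c1cccc(-c2ccc(OCC)cc2)c1` stands second highest of the three numbers seen so far in an assay on COS-7 cells for inhibition of patatin-like phospholipase domain-containing protein 2 (Mus musculus), tested at 200 uM (on this read-out higher numbers stand for more inhibition at the one concentration tested (going by the name of the read-out) and lower numbers for less inhibition), where compound 3 gives 48%. Compound 1 `CCOc1ccc(-c2cccc(C)c2)cc1` gives 54% in this assay, a number within the scatter of compound 3, and compound 2 `CCOc1ccc(-c2cccc(C(=O)O)c2)cc1` gives 23%, the lowest of the three. Two steps join the measured compounds: a number 31 percentage points lower from compound 1 to compound 2 (beyond the scatter) and a number 25 percentage points higher from compound 2 to compound 3 (beyond the scatter). Compound 4 `CCOc1ccc(-c2cccc(C(=O)OCCOC)c2)cc1` differs from compound 3 in one place: methoxy in place of butyl on a saturated chain carbon, two bonds along the chain from an oxygen next to a carbonyl group. Among the compounds with values here, of the measured steps only a number 25 percentage points higher from compound 2 to compound 3 (beyond the scatter) bears on it, a modest step; compound 4 keeps the ester and alters only the chain on that oxygen, a smaller change than the one between compound 2 and compound 3. The number for compound 4 is thus expected to stay near compound 3, with room to drop part of the way toward the acid. The step expected from this change is a number 8 percentage points lower from compound 3 to compound 4 (within the scatter). Compound 4 is expected to give 40% in this assay, between 25% and 55%.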

Compound 4, a percentage reported as inhibition, at one concentration (the size of the read-out at that concentration, not a potency): 89%
Estimate against measurement, compound 4: 49 percentage points below; measured number outside the range, above it.
By their numbers in this assay, from the lowest: compound 2; then compounds 3 and 1 (each within the scatter of the next); then compound 4.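

In this assay, within the data shown here, the chain on the oxygen next to a carbonyl group matters in its own right: hexyl to 2-methoxyethyl gives a number 41 percentage points higher from compound 3 to compound 4 (beyond the scatter), a change the earlier compounds, which held only hexyl or hydrogen there, could not reveal. With 2-methoxyethyl in place of hydrogen on that oxygen the step is a number 66 percentage points higher from compound 2 to compound 4 (beyond the scatter), and (2-methoxyethoxy)carbonyl in place of methyl on the aromatic carbon gives a number 35 percentage points higher from compound 1 to compound 4 (beyond the scatter), so this ester is the first compound shown to stand clear of all the others. Nothing measured here explains the rise.

The compounds shown leave open whether the oxygen within the 2-methoxyethyl chain is needed, which a butyl ester on the same core would test. They also leave open whether a terminal hydroxyl or amine on that chain would hold the number.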